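The source may hold more compounds than are shown below. What is called first, only, known or untested is meant among the compounds shown, and "the series" means these compounds.

Measured compounds:
- compound 1, `O=S(=O)(c1cccc(F)c1)c1cn(C2CCNC2)c2ccc(Cl)cc12`: "not determined" (no result reported) in a functional assay on HeLa cells for agonist activity at 5-hydroxytryptamine receptor 6 (Homo sapiens), read by cAMP accumulation and immunoassay, with a stated time of 10 min; on this read-out higher numbers stand for larger maximal responses and lower numbers for smaller maximal responses
- compound 2, `O=S(=O)(c1cccc2ccccc12)c1cn(C2CCCNC2)c2ccccc12`: "not determined" (no result reported)
- compound 3, `CCN1CCCC(n2cc(S(=O)(=O)c3cccc(F)c3)c3cc(OC)ccc32)C1`: 50%

Compound 1 stands without a number: in this assay compound 1 is recorded as "not determined" (no result reported), and compound 2 likewise as "not determined" (no result reported). The only figure in this set comes from compound 3, which in this assay reaches 50%. Compound 4, `O=S(=O)(c1cccc(F)c1)c1cn(C2CCNC2)c2ccccc12`, differs from compound 1 in one place: hydrogen in place of chloro on an aromatic carbon. No measured step between compound 1 and compound 4 exists, and compound 1 itself offers no number to start from, so the size and direction of this change in this assay cannot be read off any pair shown here; the step remains open. Among the measured compounds shown here, the single value of compound 3 is the only anchor available. Compound 4 is therefore expected to give about 50%, between 20% and 90%.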

Compound 4, largest response reached (Emax), in percent of the reference or control that the assay uses: 38%
Beside the measured number, compound 4's estimate is 12 percentage points above it, and the stated range covers the measured number.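

In this assay, among the compounds shown here, compound 4 gives 38% while compound 1 is recorded as "not determined" (no result reported), and no step between them can be read. Going by these compounds, what replacing chloro with hydrogen does to the maximal response stays open. No evidence shown bears on the result for compound 4.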